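Adenosine A3 series: removing the carboxy group from compound 3

This account rests on a few compounds, and the source may have more. Where it says the series, first, only, none or still open, it means among the compounds named here.

Measured so far:
compound 1 `CCn1c(-c2ccccc2)nc2c(NC3CCC3)ncnc21` — 84 nM
compound 2 `CCn1c(-c2ccccc2)nc2c(NC3CCOC3)ncnc21` — 1660 nM
compound 3 `Cn1c(-c2ccc(C(=O)O)cc2)nc2c(NC3CCCC3)ncnc21` — 25700 nM

In an assay on CHO cells for displacement of a labelled ligand from adenosine receptor A3 (Homo sapiens), read by scintillation counting, with a stated time of 3 h (on this read-out lower numbers stand for stronger inhibition and higher numbers for weaker inhibition), compound 3 gives the highest number of the three; compound 2 lies nearest, and compound 1 is furthest away. Among the compounds with values here, the only single-point step measured, a 20-fold higher number from compound 1 to compound 2 (1.30 log units; beyond the scatter), concerns the ring on the nitrogen and does not touch the position changed here.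

Compound 4 `Cn1c(-c2ccccc2)nc2c(NC3CCCC3)ncnc21` differs from compound 3 by hydrogen in place of carboxy on an aromatic carbon. Within the data shown here, no measured pair covers this change, so the expectation rests on where compound 3 stands: its value in this assay is far from that of compound 1, and compound 1 carries no carboxy on the phenyl ring. Among the measured compounds shown here, on that basis compound 4 is expected to give a much lower number than compound 3, the step being estimated as a 130-fold lower number from compound 3 to compound 4 (2.11 log units; beyond the scatter), with the uncertainty wide because no step in the data addresses this position directly. The estimate for compound 4 is 200 nM, expected to fall between 30 nM and 1500 nM.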

Compound 4, inhibition constant: 846 nM
The estimate for compound 4 lay 4.2-fold (0.63 log units) below the measured number; the range from low to high includes it.
By their numbers in this assay, from the lowest: compound 1; then compounds 4 and 2 (each within the scatter of the next); then compound 3.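

Within the data shown here, the pair gives the first direct reading at this position: in this assay there is a 30-fold lower number from compound 3 to compound 4 (1.48 log units; beyond the scatter), with hydrogen in place of carboxy on an aromatic carbon. The change is confined to one place, para to a large group, so on this core the higher number of compound 3 goes with the carboxy group, in this single pair only. Nothing measured here explains the size of the step.

As far as these compounds go, whether an amine, a primary amide or a methyl ester at the same place would give a number nearer to compound 3 or to compound 4 remains open. Also open, from the compounds shown here alone, is whether the step from carboxy to hydrogen would hold with cyclobutyl or oxolan-3-yl on the nitrogen.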